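This account rests on a few compounds, and the source may have more. Where it says the series, first, only, none or still open, it means among the compounds named here.

Measured compounds:
- compound 1, `CCOC(=O)C1=C(Nc2ccccc2)S/C(=C\c2ccc(OC)cc2)C1=O`, 9.6%
- compound 2, `CCOC(=O)C1=C(Nc2ccccc2)S/C(=C\c2cc(OC)ccc2OC)C1=O`, 30.7%

In a functional assay on K562 cells (Homo sapiens) for inhibition, read by MTT assay, with a stated time of 72 h, tested at 10 uM (on this read-out higher numbers stand for more inhibition at the one concentration tested (going by the name of the read-out) and lower numbers for less inhibition), compound 1 gives 9.6%, the lower of the two numbers measured. Compound 2, which carries two methoxy groups on its phenyl ring instead of one, gives 30.7% in this assay, and the gap between the two numbers is wider than the usual scatter, so compound 1 sits clearly at the bottom of what has been measured so far.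

Compound 3, `CCOC(=O)C1=C(Nc2ccccc2)S/C(=C\c2ccc[nH]2)C1=O`, has not yet been tested. It differs from compound 1 in one place: 1H-pyrrol-2-yl in place of 4-methoxyphenyl on a double-bonded chain carbon bound to a double-bonded ring carbon. For the measured compounds named here, nothing measured so far shows what a five-membered ring with a nitrogen does at this position, since both measured compounds carry a six-membered carbon ring there. Going by the values given here, with no comparable step available, the expectation is a change in this assay from compound 1 to compound 3 of about a number 5.4 percentage points higher from compound 1 to compound 3 (within the scatter), that is, nothing beyond the scatter. Compound 3 is therefore expected to give roughly 15%, within a range from 0% to 45%.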

Compound 3, a percentage reported as inhibition, at one concentration (the size of the read-out at that concentration, not a potency): 16.2%
For compound 3 the middle estimate is 1.2 percentage points below the measured one; the range from low to high includes it.
By their numbers in this assay, from the lowest: compounds 1 and 3 (each within the scatter of the next); then compound 2.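

For the compounds shown here, replacing 4-methoxyphenyl with 1H-pyrrol-2-yl in this assay gives a number 6.6 percentage points higher from compound 1 to compound 3 (within the scatter) and offers the first direct comparison at this position, on a double-bonded chain carbon bound to a double-bonded ring carbon. The exchange is a large one on paper: a six-membered aromatic ring of carbon only gives way to a five-membered aromatic ring with 1 hetero atom, the group shrinks from 8 heavy atoms to 5, and a hydrogen-bond acceptor is replaced by a hydrogen-bond donor, yet the read-out does not move beyond the usual scatter. No measurement is available here that would explain this result.

On these data alone, it remains open whether another five-membered ring, such as furan-2-yl, would give a similar number at this position, or whether a phenyl ring carrying a dimethylamino group or a carboxylic acid would change the picture. As far as these compounds go, since each number comes from a single concentration, the potency of compound 1 and compound 3 also remains open.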